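A few compounds are considered here, and "the series" means these few. Any claim that something is new, unique, unknown or untested is made for them only; others in the source may bear on it.

Measured in an assay on HEK293 cells for positive allosteric modulation of metabotropic glutamate receptor 2 (Rattus norvegicus), read by thallium flux; on this read-out lower numbers stand for an effect already at smaller amounts and higher numbers for an effect only at larger amounts of compound:
compound 1 `O=C(O)c1cc(-c2cccc(COc3ccc4c(c3)CN(c3ccccc3)C4=O)c2)ccc1Cl`: 260 nM
compound 2 `O=C(O)c1cc(-c2cccc(COc3ccc4c(c3)CCN(C3CCCC3)C4=O)c2)ccc1Cl`: 300 nM

Compound 1 gives the lower of the two numbers, but compound 2 lies within the usual scatter of it, so the two are not separated. Compound 3 `O=C(O)c1cc(-c2cccc(COc3ccc4c(c3)CN(C3CC3)C4=O)c2)ccc1Cl` is not yet measured. It differs from compound 1 by cyclopropyl in place of phenyl on an amide-type nitrogen in a ring. Among the measured compounds shown here, no step between measured compounds isolates this change; compound 2 shows only that a non-aromatic carbon ring on the amide-type nitrogen, in an otherwise different core, gives a number close to that of compound 1. For compound 3 a small shift toward higher numbers is expected in this assay, a 1.5-fold higher number from compound 1 to compound 3 (0.19 log units; within the scatter), probably not beyond the scatter. Compound 3 is estimated at 400 nM, range 150 nM to 1200 nM.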

Compound 3, half-maximal effective concentration: 220 nM
The estimate for compound 3 lay 1.8-fold (0.26 log units) above the measured number; the measured number falls inside the stated range.
By their numbers in this assay, from the lowest: compounds 3, 1 and 2 (each within the scatter of the next).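

In this assay, cyclopropyl in place of phenyl on the amide-type nitrogen in a ring gives a 1.2-fold lower number from compound 1 to compound 3 (0.07 log units; within the scatter) on an otherwise unchanged core. Among the compounds shown here, this is the first direct reading at this position: an aromatic ring on this nitrogen is not needed to keep the number in this range, and a three-membered non-aromatic ring of carbon serves alike. No data shown account for this.

Open, on these data alone, is whether a longer chain such as n-butyl, or a ring carrying an amine, on this nitrogen keeps the number in this range in this assay. Also open, as far as these compounds go, is whether cyclopropyl behaves alike on the core of compound 2.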